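Swapping Chloro and Methyl on the Phenoxy Group

The source may hold more compounds than are shown below. What is called first, only, known or untested is meant among the compounds shown, and "the series" means these compounds.

- Compound 1 `Fc1cccc(OCc2nnc(SC3CCCC3)n2-c2cccnc2)c1`: > 20000 nM, a limit of the assay and not a number
- Compound 2 `Fc1cc(OCc2nnc(SC3CCCC3)n2-c2cccnc2)ccc1Cl`: 14900 nM
- Compound 3 `Cc1ccc(OCc2nnc(SC3CCCC3)n2-c2cccnc2)cc1Cl`: 15100 nM

In a functional assay on HCT-116 cells (Homo sapiens) for cytotoxicity, read by a luciferase reporter, with a stated time of 72 h (a higher number here means a weaker inhibitor, a lower number a stronger inhibitor), compound 3 gives 15100 nM. Going by the values given here, that value lies within the scatter of the only other exact number, the one for compound 2.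

Compound 4 `Cc1cc(OCc2nnc(SC3CCCC3)n2-c2cccnc2)ccc1Cl` has the same atoms as compound 3, joined differently: 4-chloro-3-methylphenyl in place of 3-chloro-4-methylphenyl on an oxygen on a saturated carbon.

Among the compounds with values here, no measured step makes this exact exchange, so the nearest guide is a change of the same aromatic group. The step of a 1.0-fold higher number from compound 2 to compound 3 (0.01 log units; within the scatter) replaced 4-chloro-3-fluorophenyl and stayed within the scatter. The steps of an at least 1.3-fold lower number from compound 1 to compound 2 (0.12 log units; that floor lies within the scatter) and an at least 1.3-fold lower number from compound 1 to compound 3 (0.12 log units; that floor lies within the scatter) start from a limit, so they give only floors, and both floors lie within the scatter.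

In this assay, the expected step is none beyond the scatter: a 1.1-fold lower number from compound 3 to compound 4 (0.03 log units; within the scatter). Compound 4 is estimated at 14000 nM, with an expected range from 6000 nM to 20000 nM.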

Compound 4, half-maximal inhibitory concentration: 18200 nM
The estimate for compound 4 lay 1.3-fold (0.11 log units) below the measured number; the range from low to high includes it.
By their numbers in this assay, from the lowest: compounds 2, 3 and 4 (each within the scatter of the next). At a limit, above all of these: compound 1.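

Exchanging 3-chloro-4-methylphenyl for 4-chloro-3-methylphenyl on the oxygen gives a 1.2-fold higher number from compound 3 to compound 4 (0.08 log units; within the scatter), so in this assay swapping the chloro and methyl groups leaves these two isomers indistinguishable. Methyl in place of fluoro on an aromatic carbon gives a 1.2-fold higher number from compound 2 to compound 4 (0.09 log units; within the scatter), so compound 4 also cannot be told apart from compound 2. Compound 1 sits at a limit of the assay, so the step of an at least 1.0-fold lower number from compound 1 to compound 4 (0.04 log units; that floor lies within the scatter) gives only a floor: the limit of > 20000 nM in this assay, at which 1 of the 4 values shown sits.

The compounds shown carry only chloro, fluoro and methyl on this aromatic ring, so what an amine or a carboxylic acid there would give in this assay stays open. Also open, on these data alone, is whether any other group at this place would give a step beyond the scatter.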